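Two Measured Compounds and a Predicted Cyclopropyl Acrylamide

The source may report more compounds than this note shows. Statements on the series, on what has been measured and on what is new or still open speak of the compounds shown alone.

compound 1 `NNC(=O)CCc1ccncc1-c1ccc2ccccc2c1`: 102%
compound 2 `Cn1ccc2cc(-c3cnccc3/C=C/C(=O)N3CCOCC3)ccc21`: 97%

Of the compounds shown here, two have been measured in an assay on a protein complex for inhibition of CDK8/Cyclin C (Homo sapiens), with a stated time of 1 h, tested at 10 uM; on this read-out higher numbers stand for more inhibition at the one concentration tested (going by the name of the read-out) and lower numbers for less inhibition. Compound 1 `NNC(=O)CCc1ccncc1-c1ccc2ccccc2c1` gives 102%, and compound 2 `Cn1ccc2cc(-c3cnccc3/C=C/C(=O)N3CCOCC3)ccc21` gives 97%. Compound 1 stands at the top of the two figures, yet the gap to compound 2 falls within the usual scatter, so the two compounds cannot be told apart on these numbers; both give a high number, level with each other, at the single concentration tested.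

Compound 3 `O=C(/C=C/c1ccncc1-c1ccc2ccccc2c1)NC1CC1` has not yet been measured in this assay. It differs from compound 1 in one place: 2-(cyclopropylcarbamoyl)ethenyl in place of 2-(aminocarbamoyl)ethyl on an aromatic carbon. Going by the values given here, no step between two measured compounds covers this change, so the expectation rests on the fact that both measured compounds, with quite different amide ends, already reach the ceiling of the read-out.

Compound 3 is therefore expected to give a number close to compound 1, with the step of a number 5 percentage points lower from compound 1 to compound 3 (within the scatter) estimated to lie within the scatter. The estimate for compound 3 is 97%, with a range from 85% to 105%.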

Compound 3, a percentage reported as inhibition, at one concentration (the size of the read-out at that concentration, not a potency): 102%
Compound 3: middle estimate off by 5 percentage points, on the low side; low and high end bracket the measured number.
By their numbers in this assay, from the lowest: compounds 2, 1 and 3 (each within the scatter of the next).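

In this assay, the change at the aromatic carbon opposite the ring nitrogen and ortho to a large group gives no change at the digits printed from compound 1 to compound 3 (within the scatter) when 2-(cyclopropylcarbamoyl)ethenyl takes the place of 2-(aminocarbamoyl)ethyl. The position therefore accepts a larger group that brings in a three-membered carbon ring and an additional double bond outside aromatic rings, with fewer hydrogen-bond donors and acceptors, and this assay still shows no difference beyond the scatter. No measurement given here bears on what lies behind this result.

At a single concentration, with both numbers this high, the read-out cannot show whether the change leaves potency the same or shifts it in a way hidden at the top of the scale. Also open, from the compounds shown here alone, is which part of the change the result rests on, since the ethenyl link and the cyclopropyl amide changed together, and whether the same position would hold up with an amine, a carboxylic acid or a longer chain in place of this group.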